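This account rests on a few compounds, and the source may have more. Where it says the series, first, only, none or still open, it means among the compounds named here.

In a functional assay on WI-38 VA13 cells (Homo sapiens) for cytotoxicity (a lower number here means that less compound is needed, a higher number that more compound is needed for the effect), compound 1 `O=C(Nc1ccc2nc(NC(=O)C3CCCCC3)sc2c1)c1cccc(Oc2ccccc2)c1` gives > 4 ug/mL, which is a limit of the assay and not a number. Compound 2 `O=C(Nc1ccc2nc(NC(=O)C3CCCCC3)sc2c1)c1ccc(Br)cc1` gives > 4 ug/mL, likewise a limit. Compound 3 `O=C(Nc1ccc2nc(NC(=O)C3CCCCC3)sc2c1)c1c(F)cccc1C(F)(F)F` gives 0.032 ug/mL.

Compound 2 thus stands only at a limit of this assay, where (the limit of > 4 ug/mL in this assay, at which 2 of the 3 values shown sit). Compound 4 `Cc1nc(C)c(C(=O)Nc2ccc3nc(NC(=O)C4CCCCC4)sc3c2)s1` has not been measured; it differs from compound 2 in one place (2,4-dimethyl-1,3-thiazol-5-yl in place of 4-bromophenyl on a carbonyl carbon). Within the data shown here, no step between two measured compounds of this set is on record, so the size of this change cannot be read from a neighbour. Compound 3 shows that a number is reachable here, but compound 2 itself offers no number to start from. The step from compound 2 is expected to be a number no higher from compound 2 to compound 4 (the limit leaves the size open), no clear change beyond the scatter. Compound 4 is estimated at 4 ug/mL, between 1 ug/mL and 12 ug/mL.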

Compound 4, half-maximal effective concentration: 0.39 ug/mL
The estimate for compound 4 lay 10-fold (1.01 log units) above the measured number, and the stated range ends above it.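

In this assay, the group on this carbonyl carbon clearly matters: 2,4-dimethyl-1,3-thiazol-5-yl in place of 4-bromophenyl gives an at least 10-fold lower number from compound 2 to compound 4 (1.01 log units; beyond the scatter). Among these compounds, this is the only step that can be read here, and it shows that a five-membered aromatic ring with 2 hetero atoms can yield a number where 4-bromophenyl yields only a limit. The full size of the step stays unknown because compound 2 stands at that limit: the limit of > 4 ug/mL in this assay, at which 2 of the 4 values shown sit.

The compounds shown do not separate the part played by the ring atoms from that of the two methyl groups. From the compounds shown here alone, how an unsubstituted thiazole or a pyridine ring would read here also remains open.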